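Trimming the aryl group of a urea series

The compounds below may be only part of what the source reports. "The series", "measured", "known", "first", "only" and "open" are said of these compounds alone.

Measured so far in a functional assay on HepG2 cells (Homo sapiens) for inhibition, with a stated time of 72 h; on this read-out lower numbers stand for stronger inhibition and higher numbers for weaker inhibition:
compound 1 `COc1ccc(NC(=O)Nc2nc(Sc3c[nH]c4ccccc34)cc(N3CCCCC3)n2)cc1`: 17100 nM
compound 2 `Cc1ccc(C)c(NC(=O)Nc2nc(Sc3c[nH]c4ccccc34)cc(N3CCCCC3)n2)c1`: 6440 nM
compound 3 `Cc1cc(Cl)ccc1NC(=O)Nc1nc(Sc2c[nH]c3ccccc23)cc(N2CCCC2)n1`: 7150 nM

Compound 2 has the lowest number of the three, but compound 3 sits within the scatter of it, so only compound 1 is clearly apart. Compound 4 `O=C(Nc1ccccc1)Nc1nc(Sc2c[nH]c3ccccc23)cc(N2CCCCC2)n1` differs from compound 2 in one place: phenyl in place of 2,5-dimethylphenyl on an amide-type nitrogen. Within the data shown here, one measured step touches the same aryl group: a 2.7-fold lower number from compound 1 to compound 2 (0.42 log units; beyond the scatter), which shows that this position can move the number by a modest amount. Removing the two methyl groups is a smaller change than swapping methoxy for two methyls, so a modest rise in this assay, or none beyond the scatter, is expected, giving a 1.6-fold higher number from compound 2 to compound 4 (0.19 log units; within the scatter). Compound 4 is estimated at 10000 nM, with a range of 4000 nM to 25000 nM.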

Compound 4, half-maximal inhibitory concentration: 20900 nM
Beside the measured number, compound 4's estimate is 2.1-fold (0.32 log units) below it; the measured number falls inside the stated range.
By their numbers in this assay, from the lowest: compounds 2 and 3 (each within the scatter of the next); then compounds 1 and 4 (each within the scatter of the next).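

Taking off both methyl groups is not a neutral trim: the change gives a 3.2-fold higher number from compound 2 to compound 4 (0.51 log units; beyond the scatter) in this assay and so loses what the 2,5-dimethylphenyl group had gained. Phenyl and 4-methoxyphenyl cannot be told apart, with a 1.2-fold higher number from compound 1 to compound 4 (0.09 log units; within the scatter) on this read-out, so the methoxy group makes no visible difference here. No measurement shown explains the step. Open questions are whether one methyl group alone would keep the lower number, and how an amine or a hydroxyl group on the phenyl ring would read.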